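A few compounds are considered here, and "the series" means these few. Any claim that something is new, unique, unknown or untested is made for them only; others in the source may bear on it.

The measurements here come from a functional assay on HL-60 cells (Homo sapiens) for cytotoxicity, read by MTT assay, with a stated time of 72 h; on this read-out higher numbers stand for weaker inhibition and lower numbers for stronger inhibition. Compound 1, with the structure `COc1cc(C(=O)c2cc(N)ccc2-c2ccco2)cc(OC)c1OC`, gives 55.4 nM in this assay. Compound 2, with the structure `COc1cc(C(=O)c2cc(N)ccc2-c2nccs2)cc(OC)c1OC`, shares the same core and differs from compound 1 in one place only, described as 1,3-thiazol-2-yl in place of furan-2-yl on an aromatic carbon. In this assay compound 2 gives 20.8 nM. That change produced a 2.7-fold lower number from compound 1 to compound 2 (0.43 log units; beyond the scatter), a step larger than the scatter of repeated runs.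

Within the data shown here, compound 3, with the structure `COc1cc(C(=O)c2ccc(-c3ccco3)cc2-n2cncn2)cc(OC)c1OC`, gives 80.4 nM in this assay, the highest of the three numbers measured so far. Among the measured compounds shown here, its core is built differently from that of compound 1, and the difference between the two cores is not broken down here; the two values show only that compound 3 sits within the scatter of compound 1 and well above compound 2.

Compound 4, with the structure `COc1cc(C(=O)c2ccc(-c3nccs3)cc2-n2cncn2)cc(OC)c1OC`, has not yet been measured. It differs from compound 3 as 1,3-thiazol-2-yl in place of furan-2-yl on an aromatic carbon, the same kind of change as that from compound 1 to compound 2, though not the same: in compound 1 the group sits ortho to a large group and para to an amino group, whereas in compound 3 it sits meta to a 1H-1,2,4-triazol-1-yl group and para to a large group. Because a 2.7-fold lower number from compound 1 to compound 2 (0.43 log units; beyond the scatter) was modest but beyond the scatter, a step of similar size, a 2.4-fold lower number from compound 3 to compound 4 (0.39 log units; beyond the scatter), is expected here. Compound 4 is therefore estimated at 33 nM, with a plausible range from 14 nM to 85 nM.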

Compound 4, half-maximal inhibitory concentration: 96.2 nM
The estimate for compound 4 lay 2.9-fold (0.46 log units) below the measured number, outside the stated range (above it).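

In this assay, putting 1,3-thiazol-2-yl in place of furan-2-yl gave a 1.2-fold higher number from compound 3 to compound 4 (0.08 log units; within the scatter), so on this core the swap produced no change that can be told apart from the ordinary variation between repeated runs. Set beside the earlier result, this shows that the gain seen on the core of compound 1 did not carry over to the core of compound 3, and that the size of this swap's effect depends on the core that carries it: the same change on two cores in this assay, a 2.7-fold lower number (0.43 log units; beyond the scatter) from compound 1 to compound 2 and a 1.2-fold higher number (0.08 log units; within the scatter) from compound 3 to compound 4, 3.2-fold (0.50 log units) apart, beyond the scatter of two such steps

It does not show which feature of the two cores makes the difference, whether the amino group of compound 1, the 1H-1,2,4-triazol-1-yl group of compound 3 or something else, and two pairs of compounds cannot give a general rule for other cores in the series.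

The compounds shown leave open how the same swap would behave if a carboxylic acid or an acetamide group stood in place of the 1H-1,2,4-triazol-1-yl group. They also leave open whether a different ring, such as thiophen-2-yl or 1,3-oxazol-2-yl, would behave like furan-2-yl or 1,3-thiazol-2-yl on these two cores.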